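Dropping the Methoxy Group from Compound 1: Cytotoxicity Outlook

The source may hold more compounds than are shown below. What is called first, only, known or untested is meant among the compounds shown, and "the series" means these compounds.

Compound 1 `COc1ccccc1C1CC(c2cc3ccccc3o2)=NN1C(=O)c1ccncc1` was examined in an ADME assay on Vero cells (Chlorocebus sabaeus) for cytotoxicity, read by MTT assay, with a stated time of 72 h; a lower number here means a stronger inhibitor, a higher number a weaker inhibitor. In this assay compound 1 gives > 202000 nM, which is a limit of the assay rather than a number. Two companions share its core. In this assay compound 2 `COc1ccc(C2CC(c3cc4ccccc4o3)=NN2C(=O)c2ccncc2)c(O)c1` gives > 190000 nM, again a limit. In this assay compound 3 `O=C(c1ccncc1)N1N=C(c2cc3ccccc3o2)CC1c1ccccc1[N+](=O)[O-]` gives > 245000 nM, also a limit. Compound 1 thus stands among three compounds that all reach only a limit, with the lines (the limit of > 190000 nM in this assay, at which 1 of the 3 values shown sits), the limit of > 202000 nM in this assay, at which 1 of the 3 values shown sits, and the limit of > 245000 nM in this assay, at which 1 of the 3 values shown sits, marking where each sits. The steps between them cannot be read: a step that the two limits leave unreadable from compound 1 to compound 2, a step that the two limits leave unreadable from compound 1 to compound 3 and a step that the two limits leave unreadable from compound 2 to compound 3.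

Compound 4 `O=C(c1ccncc1)N1N=C(c2cc3ccccc3o2)CC1c1ccccc1` has not yet been measured. It differs from compound 1 in a single place (hydrogen in place of methoxy on an aromatic carbon). Within the data shown here, no measured step gives a readable size for this change; the steps from compound 1 to compound 2 and to compound 3 touch the same part of the molecule, yet both remain unreadable. What the three measured compounds do show is that none leaves the limit. Compound 4 is therefore expected to sit at a limit as well, and the step that the limit leaves unreadable from compound 1 to compound 4 is expected to be no larger than scatter. The estimate for compound 4 in this assay is 250000 nM, expected to fall between 100000 nM and 600000 nM.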

Compound 4, half-maximal inhibitory concentration: > 209000 nM
Compound 4: a limit, no number; the forecaster's own chance of this, stated with the estimate: 80%; the middle value is on the limit's open side.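

In this assay compound 4 gives > 209000 nM, which is again a limit of the assay. Its steps to compound 1, compound 2 and compound 3 therefore cannot be read. The compounds shown leave open whether any of these changes on the shared core alters the value in this assay, and by how much.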